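A few compounds are considered here, and "the series" means these few. Any claim that something is new, unique, unknown or untested is made for them only; others in the source may bear on it.

Compound 1 `CCCCCn1c(N)nc2ccccc21` is the starting point of this comparison. Going by the values given here, in an assay on HEK293 cells for agonist activity at Toll-like receptor 8 (Homo sapiens), read by reporter gene assay (on this read-out lower numbers stand for an effect already at smaller amounts and higher numbers for an effect only at larger amounts of compound), compound 1 gives 3230 nM, the highest of the two numbers measured so far; its nearest neighbour is compound 2 `CCCCCn1c(N)nc2c(C)cccc21`, which in this assay gives 1130 nM. The two share the same core and differ only by a methyl in place of hydrogen on an aromatic carbon.

Compound 3 `CCCCCn1c(N)nc2cc(C)ccc21` has not yet been measured. It differs from compound 1 by methyl in place of hydrogen on an aromatic carbon. Among the compounds with values here, the one measured step that bears on this change is the methyl addition at another aromatic carbon of the same core, where the number moved by a 2.9-fold lower number from compound 1 to compound 2 (0.46 log units; beyond the scatter). That step is modest but clears the scatter, and no other methyl position has been tested, so whether a methyl at this second place acts alike is open. A step of comparable direction but smaller size is therefore expected, roughly a 1.8-fold lower number from compound 1 to compound 3 (0.25 log units; within the scatter). Compound 3 is accordingly estimated at 1800 nM, in a range from 700 nM to 4500 nM.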

Compound 3, half-maximal effective concentration: 4570 nM
For compound 3 the middle estimate is 2.5-fold (0.40 log units) below the measured one; measured number outside the range, above it.
By their numbers in this assay, from the lowest: compound 2; then compounds 1 and 3 (each within the scatter of the next).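

In this assay, a methyl in this place, on an aromatic carbon meta to a fused ring and para to a fused ring, gives a 1.4-fold higher number from compound 1 to compound 3 (0.15 log units; within the scatter) and so cannot be told apart from the unsubstituted core of compound 1. The same exchange of hydrogen for methyl at the other aromatic carbon gave a 2.9-fold lower number from compound 1 to compound 2 (0.46 log units; beyond the scatter) and lay beyond the scatter, so the outcome of this small change on the shared core depends on where the methyl sits, at least across the two places shown. Nothing shown explains why the two places differ.

The compounds shown leave open whether a group other than methyl in this same place, such as a chlorine, a methoxy group, an amine or a carboxylic acid, would shift the number beyond the scatter in either direction. They also leave open how a methyl behaves on the remaining aromatic carbons of the ring, and whether the step seen for compound 2 would persist with a longer chain on the ring nitrogen.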